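This account rests on a few compounds, and the source may have more. Where it says the series, first, only, none or still open, it means among the compounds named here.

The study opens with two carboxylic acids on a shared core. Compound 1 `C=CC1=C(C(=O)O)C(c2ccc(F)cc2)OC1` carries a fluoro on its aromatic ring. In a functional assay on A549 cells (Homo sapiens) for cytotoxicity, read by MTT assay, with a stated time of 24 h (on this read-out lower numbers stand for stronger inhibition and higher numbers for weaker inhibition), compound 1 gives only a limit, > 100000 nM. Compound 2 `C=CC1=C(C(=O)O)C(c2ccc(OC)cc2)OC1` carries a methoxy there instead. In this assay compound 2 likewise gives only a limit, > 100000 nM. The step that the two limits leave unreadable from compound 1 to compound 2 therefore has no readable size, the reason being (the limit of > 100000 nM in this assay, at which 2 of the 2 values shown sit). Compound 2 thus stands at the edge of what this assay reports, with no number of its own. Compound 3 `C=CC1=C(C(=O)Nc2ccccc2)C(c2ccc(OC)cc2)OC1` differs from compound 2 by anilino in place of hydroxy on a carbonyl carbon. Among the compounds with values here, no measured step bears on this change, and the single step recorded, between the two aromatic substituents, is itself unreadable, so the data point in no direction. Compound 3 is therefore expected to remain weak, with an estimated 80000 nM (range 20000 nM to 300000 nM). The step of an at least 1.2-fold lower number from compound 2 to compound 3 (0.09 log units; that floor lies within the scatter) is expected to be modest at most.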

Compound 3, half-maximal inhibitory concentration: > 100000 nM
Compound 3: only a limit was reported (the forecaster's own chance of this, stated with the estimate: 55%); middle value at least 1.2-fold (0.09 log units) away from the limit.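

In this assay compound 3 gives > 100000 nM, which is a limit and not a number. The step from compound 2 to compound 3 cannot be read, because both compounds end at the same limit: the limit of > 100000 nM in this assay, at which 3 of the 3 values shown sit. The compounds shown leave open whether any change on the shared core gives a readable value in this assay.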